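This account rests on a few compounds, and the source may have more. Where it says the series, first, only, none or still open, it means among the compounds named here.

Measured compounds:
- compound 1, `COc1ccc(/C=C/C(=O)Nc2cc3c(Nc4ccc(F)c(Cl)c4)ncnc3cc2OC)c(OC)c1`: 36600 nM
- compound 2, `COc1ccc(OC)c(/C=C/C(=O)Nc2cc3c(Nc4ccc(F)c(Cl)c4)ncnc3cc2O[C@H]2CCOC2)c1`: 36300 nM
- compound 3, `O=C(/C=C/c1ccc([N+](=O)[O-])cc1)Nc1cc2c(Nc3ccc(F)c(Cl)c3)ncnc2cc1O[C@H]1CCOC1`: 26700 nM

All three were tested in a functional assay on MCF7 cells (Homo sapiens) for cytotoxicity, read by MTT assay, with a stated time of 72 h; on this read-out higher numbers stand for weaker inhibition and lower numbers for stronger inhibition. Compound 3 gives the lowest of the three numbers, but its gaps to compound 2 and to compound 1 are both within the usual scatter, so the three compounds cannot be told apart on potency. Among the measured compounds shown here, compound 1 and compound 2 differ in two places at once, so no single step connects them; their values simply sit close together.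

The next compound, compound 4, has the structure `COc1cc(/C=C/C(=O)Nc2cc3c(Nc4ccc(F)c(Cl)c4)ncnc3cc2O[C@H]2CCOC2)cc(OC)c1O`. It differs from compound 3 in one place: 4-hydroxy-3,5-dimethoxyphenyl in place of 4-nitrophenyl on a double-bonded chain carbon bound to a double-bonded chain carbon. For the measured compounds named here, the only measured step that bears on this kind of change is the one where the aryl group on the same chain carbon was swapped, a 1.4-fold lower number from compound 2 to compound 3 (0.13 log units; within the scatter). That swap, from a dimethoxy-bearing ring to a nitro-bearing ring, left the number essentially where it was. Compound 4 brings back a ring carrying methoxy groups, now with a hydroxy group as well, and with no measured step pointing either way there is no reason to expect a shift beyond the scatter.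

Compound 4 is therefore expected to give about 30000 nM in this assay, with a plausible range from 15000 nM to 60000 nM, so that the step of a 1.1-fold higher number from compound 3 to compound 4 (0.05 log units; within the scatter) is expected to stay inside the scatter.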

Compound 4, half-maximal inhibitory concentration: 30500 nM
Compound 4: the middle estimate sits 1.0-fold (0.01 log units) below what was measured; the measured number falls inside the stated range.
By their numbers in this assay, from the lowest: compounds 3, 4, 2 and 1 (each within the scatter of the next).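

In this assay, the aryl group on a double-bonded chain carbon bound to a double-bonded chain carbon now has three versions on an otherwise identical molecule, and the new comparisons give a result of the same kind as the earlier one: there is a 1.1-fold higher number from compound 3 to compound 4 (0.06 log units; within the scatter) and a 1.2-fold lower number from compound 2 to compound 4 (0.08 log units; within the scatter). Compound 4 is the only one of these compounds whose aryl group carries a hydroxy group, and neither comparison separates it from the aryl groups with only methoxy groups or a nitro group, so at this place, three quite different sets of ring groups cannot be told apart on this read-out. No further measurement is available to explain why these numbers stay together.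

Still open, on these data alone, is whether any group at this place can move the number beyond the scatter, for example a phenyl ring carrying an amine or a carboxylic acid, or a longer chain in place of the ring. The compounds shown also leave the role of the rest of the molecule unresolved, as the only compounds with different groups on the core, compound 1 and compound 2, also differ in their aryl groups.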